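A Side-Chain Exchange on Compound 2 and Its Expected Effect

A few compounds are considered here, and "the series" means these few. Any claim that something is new, unique, unknown or untested is made for them only; others in the source may bear on it.

Of the compounds shown here, two have been measured in a functional assay on ZR-75-1 cells (Homo sapiens) for cytotoxicity, read by MTT assay, with a stated time of 72 h; a higher number here means that more compound is needed for the effect, a lower number that less compound is needed. Compound 1 `CCc1cccc2c(OC)c(-c3occ(C)c3C(=O)OC)ccc12` gives 1.3 ug/mL, and compound 2 `CCc1cccc2c(OC)c(-c3occ(C)c3CBr)ccc12` gives 4.6 ug/mL. Among the compounds with values here, compound 2 therefore holds the higher of the two numbers, its nearest neighbour being compound 1, and the single measured step is a 3.5-fold higher number from compound 1 to compound 2 (0.55 log units; beyond the scatter). Compound 3 `CCc1cccc2c(OC)c(-c3occ(C)c3COCC(F)(F)F)ccc12` is not yet measured; it differs from compound 2 by 2,2,2-trifluoroethoxy in place of bromo on a saturated chain carbon bound to an aromatic carbon. Within the data shown here, the only measured step that bears on this region is the modest one from compound 1 to compound 2, where exchanging the group at this arm of the shared core shifted the number by a modest amount; that step is the sole guide. A step of similar or smaller size in this assay is expected, so the number for compound 3 is estimated at 6 ug/mL, within a range of 2 ug/mL to 18 ug/mL. This estimate corresponds to an expected 1.3-fold higher number from compound 2 to compound 3 (0.12 log units; within the scatter).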

Compound 3, concentration for half-maximal effect: 5.3 ug/mL
The estimate for compound 3 lay 1.1-fold (0.05 log units) above the measured number, and the stated range covers the measured number.
By their numbers in this assay, from the lowest: compound 1; then compounds 2 and 3 (each within the scatter of the next).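

In this assay, the exchange of bromo for 2,2,2-trifluoroethoxy on this saturated chain carbon gives a 1.2-fold higher number from compound 2 to compound 3 (0.06 log units; within the scatter) and so stays within the scatter, even though 6 heavy atoms enter where 1 leaves; at this position, the assay does not separate these two groups. Replacing methoxycarbonyl with (2,2,2-trifluoroethoxy)methyl gives a 4.1-fold higher number from compound 1 to compound 3 (0.61 log units; beyond the scatter) and lies beyond the scatter, so compound 1 keeps the lowest number of the three, with the side chains of compound 2 and compound 3 both on the higher side of it. Nothing measured here explains either result.

The compounds shown leave open how an amine or a carboxylic acid would read on this arm of the shared core. They also leave open whether a longer chain on the same carbon would again stay within the scatter of compound 2.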